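Working notes: 4-methoxybenzyl to 4-methylbenzyl

The compounds below may be only part of what the source reports. "The series", "measured", "known", "first", "only" and "open" are said of these compounds alone.

- compound 1 `COc1ccc(Cc2nnc(NC(=O)/C(C#N)=C/c3ccccc3OS(=O)(=O)c3ccc(OC)cc3)s2)cc1` gives 78%
- compound 2 `COc1ccc(Cc2nnc(NC(=O)/C(C#N)=C/c3ccccc3OS(=O)(=O)c3ccccc3[N+](=O)[O-])s2)cc1` gives 68%
- compound 3 `COc1ccc(Cc2nnc(NC(=O)/C(C#N)=C/c3ccccc3OS(=O)(=O)c3ccc(Cl)cc3)s2)cc1` gives 79%

These values come from a functional assay on RS4-11 cells (Homo sapiens) for inhibition, read by CCK-8 assay, with a stated time of 48 h, tested at 20 uM; a lower number here means less inhibition of growth, a higher number more inhibition of growth at the concentration tested. Compound 1 lies within the scatter of both other compounds, with a number 10 percentage points lower from compound 1 to compound 2 (within the scatter) and a number 1 percentage points higher from compound 1 to compound 3 (within the scatter). Only a number 11 percentage points higher from compound 2 to compound 3 (beyond the scatter) exceeds it.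

Compound 4 `COc1ccc(S(=O)(=O)Oc2ccccc2/C=C(\C#N)C(=O)Nc2nnc(Cc3ccc(C)cc3)s2)cc1` has methyl in place of methoxy on an aromatic carbon, 4-methoxybenzyl to 4-methylbenzyl (methyl in place of methoxy on an aromatic carbon). For the measured compounds named here, no measured step changes the benzyl group. All three change the group on the sulfonyl sulfur, so they bear on this change only indirectly. The nearest is the replacement of methoxy on an aromatic carbon in compound 3, with a number 1 percentage points higher from compound 1 to compound 3 (within the scatter).

The expected result in this assay is no change beyond the scatter, a number 2 percentage points lower from compound 1 to compound 4 (within the scatter). For compound 4 the estimated value is 76%, with an expected range of 64% to 87%.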

Compound 4, percent growth inhibition at one concentration: 79%
The estimate for compound 4 lay 3 percentage points below the measured number; the range from low to high includes it.
By their numbers in this assay, from the lowest: compounds 2, 1, 3 and 4 (each within the scatter of the next, the first and the last beyond it).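

Within this assay, 4-methoxybenzyl to 4-methylbenzyl gives a number 1 percentage points higher from compound 1 to compound 4 (within the scatter), the first reading at the benzyl end of the series, since the earlier compounds varied only the group on the sulfonyl sulfur. The methoxy group at this place is therefore not required for the growth inhibition seen, as methyl can stand in its stead. Nothing measured here explains this result.

On these data alone, whether an amine, a carboxylic acid or a longer chain would hold up at this place remains open. So does whether methyl would serve equally alongside the 4-chlorophenyl or 2-nitrophenyl groups on the sulfonyl sulfur.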